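The source may report more compounds than this note shows. Statements on the series, on what has been measured and on what is new or still open speak of the compounds shown alone.

Measured so far in an ADME assay on HFF cells (Homo sapiens) for cytotoxicity; on this read-out higher numbers stand for weaker inhibition and lower numbers for stronger inhibition:
Compound 1 `NC(=O)c1cn(COC(CO)CO)c2ncnc(N)c12` gives > 320000 nM (a limit)
Compound 2 `NC(=S)c1cn(COC(CO)CO)c2ncnc(N)c12` gives > 100000 nM (a limit)

Compound 2 stands only at a limit, with no number known. Compound 3 `Nc1ncnc2c1ccn2COC(CO)CO` differs from it by a hydrogen atom in place of a group of 3 heavy atoms (1 carbon, 1 nitrogen, 1 sulfur; no ring), on an aromatic carbon. Among the measured compounds shown here, the only measured step that bears on this change is a step that the two limits leave unreadable from compound 1 to compound 2, and it gives no size to carry over. It involves a replacement within the group, not its removal. No step beyond the scatter can be supported, and none is expected in this assay: the expected step is a number no higher from compound 2 to compound 3 (the limit leaves the size open). The estimate for compound 3 is 100000 nM, with an expected range from 30000 nM to 320000 nM.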

Compound 3, half-maximal inhibitory concentration: > 100000 nM
Compound 3: a limit, no number; the forecaster's own chance of this, stated with the estimate: 75%; the middle value lies on the limit itself.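

In this assay compound 3 gives > 100000 nM, a limit and not a number. Among the compounds shown here, with compound 1 and compound 2 also at limits, no step among the three can be read. The compounds shown leave open whether the group on this aromatic carbon changes the read-out at all.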